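The compounds below may be only part of what the source reports. "The series", "measured", "known", "first", "only" and "open" are said of these compounds alone.

Working notes on the series. Compound 1 `ClCc1cc(-c2ccccc2OCc2ccc(Br)cc2)no1` and compound 2 `OCCc1cc(-c2ccccc2OCc2ccc(Br)cc2)no1` share one core and differ in a single group. In an assay with Cystic fibrosis transmembrane conductance regulator (Rattus norvegicus) as the target (a lower number here means tighter binding, a higher number weaker binding), compound 1 gives 220000 nM, and compound 2 gives 23000 nM. The step of a 9.6-fold lower number from compound 1 to compound 2 (0.98 log units; beyond the scatter) is the only one measured so far; on it, compound 2 stands lowest of the two numbers, with compound 1 as its nearest neighbour. Compound 3 `COCc1cc(-c2ccccc2OCc2ccc(Br)cc2)no1` is not yet measured. The change from compound 2 is methoxy in place of hydroxymethyl on a saturated chain carbon bound to an aromatic carbon. Within the data shown here, the one measured step bears on it only loosely: it showed that trading chloro for hydroxymethyl brought a modest gain, and the move to methoxy gives up the hydrogen-bond donor that hydroxymethyl carries while keeping one acceptor. A step back toward weaker binding is therefore expected in this assay, smaller than the measured one: a 2.6-fold higher number from compound 2 to compound 3 (0.42 log units; beyond the scatter) is the expected size. Compound 3 is estimated at 60000 nM, within 20000 nM to 200000 nM.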

Compound 3, dissociation constant: > 300000 nM
Compound 3 ended at the assay's limit; the forecaster's own chance of this, stated with the estimate: 15%; middle value at least 5.0-fold (0.69 log units) away from the limit.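

In this assay, compound 3 stands at a limit of the assay, not at a number: the limit of > 300000 nM in this assay, at which 1 of the 3 values shown sits.

On a saturated chain carbon bound to an aromatic carbon, methoxy in place of hydroxymethyl joins the same atoms differently and takes the hydrogen-bond donor count from 1 to 0, yet it gives an at least 13-fold higher number from compound 2 to compound 3 (1.11 log units; beyond the scatter), so the gain seen with compound 2 does not extend to every oxygen-bearing group at this place. The other new step, an at least 1.3-fold higher number from compound 1 to compound 3 (0.13 log units; that floor lies within the scatter), has a floor within the scatter, which leaves compound 3 unseparated from compound 1, and compound 2 alone stands apart.

As far as these compounds go, how far compound 3 lies past the limit stays open. Also open, from the compounds shown here alone, is whether the hydroxyl itself accounts for the difference, or whether an amine or a carboxylic acid at this place would match compound 2.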